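The source may report more compounds than this note shows. Statements on the series, on what has been measured and on what is new or still open speak of the compounds shown alone.

Compound 1 `CCC(=O)Nc1ccc(S(=O)(=O)Oc2ccccc2I)cc1` gives 7200 nM in a functional assay on HT-1080 cells (Homo sapiens) for antiproliferative activity, read by sulforhodamine B assay, with a stated time of 48 h; a lower number here means a stronger inhibitor, a higher number a weaker inhibitor. Compound 2 `CCCNC(=O)Nc1ccc(S(=O)(=O)Oc2ccccc2I)cc1` gives 700 nM in this assay, the lower of the two numbers, and the step of a 10-fold lower number from compound 1 to compound 2 (1.01 log units; beyond the scatter) is the only one measured so far. Compound 3 `O=C(NCC1CCCC1)Nc1ccc(S(=O)(=O)Oc2ccccc2I)cc1` differs from compound 2 by cyclopentyl in place of ethyl on a saturated chain carbon bound to an amide-type nitrogen. Among the measured compounds shown here, that earlier step changed the group on the carbonyl carbon, not the saturated chain carbon bound to the amide-type nitrogen, so no measured step bears directly on this change. The step of a 1.4-fold lower number from compound 2 to compound 3 (0.15 log units; within the scatter) is expected to stay within the scatter. Compound 3 is estimated at 500 nM, between 150 nM and 1600 nM.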

Compound 3, half-maximal inhibitory concentration: 6100 nM
The estimate for compound 3 lay 12-fold (1.09 log units) below the measured number; the measured number lies above the stated range.
By their numbers in this assay, from the lowest: compound 2; then compounds 3 and 1 (each within the scatter of the next).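

Replacing propyl with cyclopentylmethyl gives an 8.7-fold higher number from compound 2 to compound 3 (0.94 log units; beyond the scatter), so the low number of compound 2 does not carry over to every larger carbon group at this position. There is also a 1.2-fold lower number from compound 1 to compound 3 (0.07 log units; within the scatter), which shows that placing an amino link on the carbonyl carbon does not lower the number by itself; the group attached to that link matters. Nothing measured here explains this loss. The compounds shown leave open whether a longer open chain, such as butyl or pentyl, would keep the number of compound 2. They also leave open how a ring without the methylene link, such as cyclopentyl directly on the nitrogen, would behave.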